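This account rests on a few compounds, and the source may have more. Where it says the series, first, only, none or still open, it means among the compounds named here.

Measured so far:
- compound 1 `COc1ccc(C(=O)/C(=C/c2ccccc2F)CCOC(C)=O)cc1`: in a functional assay on MCF7 cells (Homo sapiens) for inhibition, read by XTT assay, with a stated time of 48 h (a higher number here means a weaker inhibitor, a lower number a stronger inhibitor), compound 1 gives > 100000 nM, which is a limit of the assay rather than a number.
- compound 2 `COc1ccc(C(=O)/C(=C/c2ccc(Cl)cc2Cl)CCOC(C)=O)cc1`: in this assay compound 2 gives 83400 nM.
- compound 3 `COc1ccc(C(=O)/C(=C/c2ccc([N+](=O)[O-])cc2)CCOC(C)=O)cc1`: in this assay compound 3 gives > 100000 nM, again a limit of the assay rather than a number.

Among the measured compounds shown here, compound 2 therefore holds the only real number among the three, since the other two sit at the limit of > 100000 nM in this assay, at which 2 of the 3 values shown sit. Even so, its step from compound 1 is small: an at least 1.1-fold lower number from compound 1 to compound 2 (0.07 log units; that floor lies within the scatter), and its step to compound 3 is equally small: an at least 1.1-fold higher number from compound 2 to compound 3 (0.07 log units; that floor lies within the scatter). Both of those steps swap the aryl group on the double-bonded chain carbon.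

Compound 4 `COc1ccc(C(=O)/C(=C/c2ccc(Cl)cc2Cl)CN(C)C(=O)c2ccccc2)cc1` changes a different part of compound 2: benzoyl(methyl)amino in place of acetoxymethyl on a saturated chain carbon bound to a double-bonded chain carbon. For the measured compounds named here, no measured step touches this position, so the measured steps give no direct guide to its size or direction. The measured steps only show that all three compounds are weak in this assay. Compound 4 is therefore expected to stay near compound 2, with an estimated step of a 1.2-fold lower number from compound 2 to compound 4 (0.08 log units; within the scatter), which lies within the scatter. The estimate for compound 4 is 70000 nM, within a range from 20000 nM to 200000 nM, with a real chance that only a limit is reported.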

Compound 4, half-maximal inhibitory concentration: > 100000 nM
Compound 4 gave a limit, no number; the forecaster's own chance of this, stated with the estimate: 40%; middle value at least 1.4-fold (0.15 log units) from the limit.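

Replacing acetoxymethyl with benzoyl(methyl)amino on a saturated chain carbon bound to a double-bonded chain carbon, the only change shown at this position, gives an at least 1.1-fold higher number from compound 2 to compound 4 (0.07 log units; that floor lies within the scatter). In this assay, compound 4 gives a limit rather than a number, so bringing in a six-membered aromatic ring and an amide-type nitrogen here does not produce a clearly stronger inhibitor, although the size of the step cannot be fixed. Compound 4 keeps the 2,4-dichlorophenyl group of compound 2 and still joins the others at the top of the measurable range: the limit of > 100000 nM in this assay, at which 3 of the 4 values shown sit.

Going by these compounds, how far compound 4 lies past its limit stays unknown, so this result cannot show whether the new group leaves the inhibition nearly unchanged or weakens it considerably. The compounds shown also leave open what a free hydroxyl, a simple dimethylamino group or a carboxylic acid would do on this same chain carbon, and whether any of them would give a number well clear of the limit.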